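A few compounds are considered here, and "the series" means these few. Any claim that something is new, unique, unknown or untested is made for them only; others in the source may bear on it.

Three compounds of a shared core were examined in an ADME assay on HEK293 cells (Homo sapiens) for antiproliferative activity, read by MTT assay, with a stated time of 24 h; a higher number here means a weaker inhibitor, a lower number a stronger inhibitor. Compound 1, `COc1ccc(-c2cc(/C=C/C(=O)c3ccc(OC)c(OC)c3)nc3cc(-c4ccccc4)nn23)cc1`, gives 48500 nM. Compound 2, `COc1ccc(C(=O)/C=C/c2cc(-c3ccc(OC)c(OC)c3)n3nc(-c4ccccc4)cc3n2)cc1OC`, carries one change relative to compound 1, namely (methoxy in place of hydrogen on an aromatic carbon), and compound 2 gives 32500 nM. That change made a step of a 1.5-fold lower number from compound 1 to compound 2 (0.17 log units; within the scatter). Compound 3, `COc1ccc(-c2cc(/C=C/C(=O)c3ccccc3)nc3cc(-c4ccccc4)nn23)cc1`, differs from compound 1 in the group on the carbonyl carbon, (phenyl in place of 3,4-dimethoxyphenyl on a carbonyl carbon), and compound 3 gives 53200 nM; the step is a 1.1-fold higher number from compound 1 to compound 3 (0.04 log units; within the scatter). All three values sit within the usual scatter of one another, so none of these compounds can be set apart from the others on this evidence.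

Compound 4, `COc1ccc(-c2cc(/C=C/C(=O)c3ccccc3)nc3cc(-c4ccccc4)nn23)cc1OC`, has not yet been measured in this assay. It differs from compound 3 by methoxy in place of hydrogen on an aromatic carbon. This is the same change that separates compound 2 from compound 1, made here on the core of compound 3; the surroundings of the place are described in the same terms in both cases, so the change is the same kind. Because the earlier step was a 1.5-fold lower number from compound 1 to compound 2 (0.17 log units; within the scatter), which lay within the scatter, compound 4 is expected to land close to compound 3, and the estimated step is a 1.4-fold lower number from compound 3 to compound 4 (0.15 log units; within the scatter). The expected value for compound 4 is 38000 nM, with a likely range from 20000 nM to 72000 nM. Going by the values given here, this expectation rests on the two measured neighbours alone and on the single earlier instance of the change.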

Compound 4, half-maximal inhibitory concentration: 51200 nM
Compound 4: middle estimate off by 1.3-fold (0.13 log units), on the low side, and the stated range covers the measured number.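

In this assay, methoxy in place of hydrogen on an aromatic carbon, which here takes 4-methoxyphenyl to 3,4-dimethoxyphenyl, gives a 1.0-fold lower number from compound 3 to compound 4 (0.02 log units; within the scatter), and this step does not differ from its earlier instance: the same change on two cores in this assay, a 1.5-fold lower number (0.17 log units; within the scatter) from compound 1 to compound 2 and a 1.0-fold lower number (0.02 log units; within the scatter) from compound 3 to compound 4, 1.4-fold (0.16 log units) apart, within the scatter of two such steps. The other change, phenyl in place of 3,4-dimethoxyphenyl on a carbonyl carbon, gives a 1.6-fold higher number from compound 2 to compound 4 (0.20 log units; within the scatter), and it too agrees with its earlier instance: the same change on two cores in this assay, a 1.1-fold higher number (0.04 log units; within the scatter) from compound 1 to compound 3 and a 1.6-fold higher number (0.20 log units; within the scatter) from compound 2 to compound 4, 1.4-fold (0.16 log units) apart, within the scatter of two such steps. Going by these compounds alone, each change therefore reads the same on both cores, but since every step lies within the scatter, this shows only that neither change separates the compounds on either core, and it does not show that a change with a measurable step would carry over in the same way.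

As far as these compounds go, the four compounds differ only in methoxy groups and in phenyl against 3,4-dimethoxyphenyl on the carbonyl carbon, so it remains open whether any change can produce a step beyond the scatter. From the compounds shown here alone, whether an amine, a carboxylic acid or a longer chain in place of a methoxy group would do so, and whether such a step would then hold from one core to another, also remains open.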